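A few compounds are considered here, and "the series" means these few. Any claim that something is new, unique, unknown or untested is made for them only; others in the source may bear on it.

In a functional assay on SK-OV-3 cells (Homo sapiens) for inhibition, read by sulforhodamine B assay, with a stated time of 48 h (a lower number here means a stronger inhibitor of growth, a higher number a weaker inhibitor of growth), two compounds of the shared core have been measured. Compound 1 `O=C(Nc1cccc(-n2cc(-c3ccncc3)c(-c3ccc(Cl)c(O)c3)n2)c1)Nc1cccc(C(F)(F)F)c1` gives 4970 nM in this assay, and compound 2 `COc1cc(-c2nn(-c3cccc(NC(=O)Nc4cc(C(F)(F)F)cc(C(F)(F)F)c4)c3)cc2-c2ccncc2)ccc1Cl` gives 1090 nM, the lower of the two numbers; the gap between them lies beyond the scatter, but the two structures differ in more than one place, so the pair shows only what its two values show.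

Compound 3 `O=C(Nc1cccc(-n2cc(-c3ccncc3)c(-c3ccc(Cl)c(O)c3)n2)c1)Nc1cc(C(F)(F)F)cc(C(F)(F)F)c1` has not yet been measured. It differs from compound 2 by hydrogen in place of methyl on an oxygen on an aromatic ring, while the bis-trifluoromethyl anilide is kept. Compound 1 carries the same hydroxy group and a weaker number, yet its other difference prevents a clean reading. The step from compound 2 to compound 3 is expected to be a modest rise, at or a little beyond the scatter, as a 2.0-fold higher number from compound 2 to compound 3 (0.30 log units; within the scatter). Compound 3 is therefore expected to give about 2200 nM, within a range from 800 nM to 6000 nM.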

Compound 3, concentration for 50% growth inhibition: 1350 nM
Compound 3: the middle estimate sits 1.6-fold (0.21 log units) above what was measured, and the stated range covers the measured number.
By their numbers in this assay, from the lowest: compounds 2 and 3 (each within the scatter of the next); then compound 1.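

In this assay, the step of a 1.2-fold higher number from compound 2 to compound 3 (0.09 log units; within the scatter) for methoxy to hydroxy shows that the methyl on this oxygen can be removed with no difference this read-out can separate. Among these compounds, the step of a 3.7-fold lower number from compound 1 to compound 3 (0.57 log units; beyond the scatter) isolates trifluoromethyl in place of hydrogen on an aromatic carbon, so of the two differences between compound 1 and compound 2, this is the one with a step beyond the scatter. No measurement at hand explains the size of either step.

As far as these compounds go, it remains open whether an ethoxy group, a longer chain on the oxygen or an amine in place of the hydroxy would stay within the scatter. Among the compounds shown here, it is also open whether the added trifluoromethyl gives a similar step when methoxy is present, since its single step here carries hydroxy.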